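Adding a Phenyl to the Core of Compound 2

This account rests on a few compounds, and the source may have more. Where it says the series, first, only, none or still open, it means among the compounds named here.

Of the compounds shown here, three built on one shared core have been tested in an assay on cells for displacement of a labelled ligand from transmembrane domain-containing protein TMIGD3 (Homo sapiens), read by scintillation counting, with a stated time of 120 min; a higher number here means a weaker inhibitor, a lower number a stronger inhibitor. Compound 1 `O=C(Nc1nccn2cc(-c3ccccc3)nc12)c1ccccc1` gives 52 nM in this assay. Compound 2 `COc1ccc(C(=O)Nc2nccn3cc(-c4ccccc4)nc23)cc1` carries a methoxy on the benzamide ring and gives 162 nM. Compound 3 `COc1ccc(-c2cn3ccnc(NC(=O)c4ccccc4)c3n2)cc1` carries a methoxy on the other phenyl ring and gives 121 nM. Compound 2 therefore shows the highest number of the three; its gap to compound 3 lies within the scatter, while the step of a 3.1-fold higher number from compound 1 to compound 2 (0.49 log units; beyond the scatter) lies beyond it.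

Compound 4 `COc1ccc(C(=O)Nc2nc(-c3ccccc3)cn3cc(-c4ccccc4)nc23)cc1` differs from compound 2 in one place: phenyl in place of hydrogen on an aromatic carbon. The entering ring sits on an aromatic carbon of the core, next to the ring nitrogen.

Neither measured step bears directly on this change. Both concern a methoxy entering on a phenyl ring, and both shifted the number upward by a modest amount, as seen in a 2.3-fold higher number from compound 1 to compound 3 (0.37 log units; beyond the scatter). Nothing in the data shows a phenyl entering on the core, so the expectation is loose. Compound 4 is expected to give about 250 nM in this assay, within a range from 70 nM to 900 nM. That estimate corresponds to a step of a 1.5-fold higher number from compound 2 to compound 4 (0.19 log units; within the scatter), expected to stay within the scatter.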

Compound 4, inhibition constant: 25 nM
Estimate against measurement, compound 4: 10-fold (1.00 log units) above; the measured number lies below the stated range.
By their numbers in this assay, from the lowest: compound 4; then compound 1; then compounds 3 and 2 (each within the scatter of the next).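

In this assay, this carbon of the core proves to be a place where a change can lower the number: phenyl in place of hydrogen gives a 6.5-fold lower number from compound 2 to compound 4 (0.81 log units; beyond the scatter). The earlier steps shown here could not show this, since both put a methoxy on a phenyl ring, away from the core, and both raised the number. The new result therefore shows that a whole added phenyl ring on the core is compatible with a stronger inhibitor, although nothing available here accounts for the gain, which stands only as an observation.

What the compounds shown leave open is whether the gain depends on having a phenyl ring at this carbon, or whether a smaller group such as methyl, a saturated ring such as cyclohexyl, or a group of another kind such as an amine or a carboxylic acid would do the same. They also leave open whether the same phenyl would lower the number to a similar degree on compound 1, which has no methoxy on its benzamide ring.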